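This account rests on a few compounds, and the source may have more. Where it says the series, first, only, none or still open, it means among the compounds named here.

Measured compounds:
- compound 1 `O=C(Nc1cccc(N2CCCC2=O)c1)C1CCCN(C(=O)c2cc(C(F)(F)F)cc(C(F)(F)F)c2)C1` — 0%
- compound 2 `O=C(Nc1ccc(Cl)cc1)C1CCCN(C(=O)c2cccc([N+](=O)[O-])c2)C1` — 0%
- compound 3 `O=C(Nc1ccc(Cl)cc1)C1CCCN(C(=O)c2cccc(-c3cccs3)c2)C1` — 4%

In an ADME assay on PC-3 cells (Homo sapiens) for cytotoxicity, read by WST assay, tested at 100 uM (on this read-out higher numbers stand for more inhibition at the one concentration tested (going by the name of the read-out) and lower numbers for less inhibition), all three numbers sit close together. Compound 1 stands level with compound 2 at the digits shown; the two share the lowest number of the three. Compound 3, with 4%, lies within the usual scatter of compound 1, so no order among the three can be read from these numbers. Among the measured compounds shown here, the one measured step, a number 4 percentage points higher from compound 2 to compound 3 (within the scatter), concerns the aroyl side of the shared core and stays within the scatter.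

Compound 4 `COc1cccc(NC(=O)C2CCCN(C(=O)c3cc(C(F)(F)F)cc(C(F)(F)F)c3)C2)c1` follows from compound 1 by the change (methoxy in place of 2-oxopyrrolidin-1-yl on an aromatic carbon). For the measured compounds named here, no measured pair in this assay touches the anilide ring of the core, so the step from compound 2 to compound 3 bears on it only in a general way: it shows that a sizeable change of a substituent left the number essentially where it was. Going by the values given here, nothing among the measured compounds gives grounds to expect compound 4 to move out of the low region occupied by all three.

The expected step is therefore a number 2 percentage points higher from compound 1 to compound 4 (within the scatter), none beyond the scatter. Compound 4 is estimated at 2%, with a range from 0% to 12%.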

Compound 4, a percentage reported as inhibition, at one concentration (the size of the read-out at that concentration, not a potency): 0%
Compound 4: middle estimate off by 2 percentage points, on the high side, within the range that was stated.
By their numbers in this assay, from the lowest: compounds 1, 2, 4 and 3 (each within the scatter of the next).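

In this assay, among the compounds shown here, the step of no change at the digits printed from compound 1 to compound 4 (within the scatter) is the first one measured on the aromatic carbon meta to a large group, on the ring of the shared core that the earlier step did not touch. Replacing 2-oxopyrrolidin-1-yl (6 heavy atoms, a five-membered non-aromatic ring) with methoxy (2 heavy atoms, no ring) therefore leaves the number unchanged at the digits printed, with the 3,5-bis(trifluoromethyl)benzoyl side held constant. So neither the ring nor the double bond outside aromatic rings in 2-oxopyrrolidin-1-yl is needed to keep this pair at the printed level, although no explanation for this can be offered from the data, as nothing measured on these compounds bears on the result.

Still open, from the compounds shown here alone, is whether a primary amine or a carboxylic acid at this position would give a number beyond the scatter, since both groups in this pair carry no net charge and no hydrogen-bond donor. Also open, going by these compounds, is whether the same exchange would behave alike on compounds carrying the nitro or thiophen-2-yl group on the other aromatic ring.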